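Shifting the Hydroxy Group on the Urea Aryl Ring

The source may report more compounds than this note shows. Statements on the series, on what has been measured and on what is new or still open speak of the compounds shown alone.

Among the compounds with values here, compound 2 `COc1cc(NC(C)CCCNC(=O)Nc2cccc(O)c2)c2ncccc2c1` gives 25000 nM in a functional assay on NCI-H460 cells (Homo sapiens) for inhibition, read by MTT assay, with a stated time of 72 h (a lower number here means a stronger inhibitor, a higher number a weaker inhibitor), one of only two numbers measured so far; compound 1 `COc1cc(NC(C)CCCNC(=O)Nc2cccc(Cl)c2)c2ncccc2c1` gives 37000 nM, and the step of a 1.5-fold lower number from compound 1 to compound 2 (0.17 log units; within the scatter) lies within the scatter. Compound 3 `COc1cc(NC(C)CCCNC(=O)Nc2ccc(O)cc2)c2ncccc2c1` differs from compound 2 by 4-hydroxyphenyl in place of 3-hydroxyphenyl on an amide-type nitrogen. Within the data shown here, no measured step covers this change: the only step known concerns a different exchange and was itself within the scatter. Compound 3 is therefore expected to give about the same number as compound 2, an estimated step of no change at the digits printed from compound 2 to compound 3 (within the scatter). The estimate for compound 3 is 25000 nM, with a range from 8000 nM to 80000 nM.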

Compound 3, half-maximal inhibitory concentration: 34000 nM
Compound 3: middle estimate off by 1.4-fold (0.13 log units), on the low side; the measured number falls inside the stated range.
By their numbers in this assay, from the lowest: compounds 2, 3 and 1 (each within the scatter of the next).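

Moving the hydroxy group, with 4-hydroxyphenyl in place of 3-hydroxyphenyl on the amide-type nitrogen, leaves the read-out in this assay within the scatter (a 1.4-fold higher number from compound 2 to compound 3 (0.13 log units; within the scatter)). The exchange of 3-chlorophenyl for 4-hydroxyphenyl at the same place is also within the scatter (a 1.1-fold lower number from compound 1 to compound 3 (0.04 log units; within the scatter)), so neither the placement of the hydroxy group nor its exchange for chloro separates these compounds. Nothing measured here bears on why these numbers stay so close.

On these data alone, it remains open whether an amine or a carboxylic acid on this ring would give a step beyond the scatter.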